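This account rests on a few compounds, and the source may have more. Where it says the series, first, only, none or still open, it means among the compounds named here.

Measured in a functional assay on HeLa cells (Homo sapiens) for antiproliferative activity, read by CCK-8 assay, with a stated time of 72 h, tested at 2 uM; a lower number here means a weaker effect, a higher number a stronger effect of the compound at the concentration tested:

Compound 1, `COc1ccc(N2CCN(C(=S)SCc3ccc(C(=O)Nc4ccccc4N)cc3)CC2)cc1`: 39.4%
Compound 2, `Nc1ccccc1NC(=O)c1ccc(CSC(=S)N2CCN(Cc3ccccc3)CC2)cc1`: 20.6%
Compound 3, `CN1CCN(C(=S)SCc2ccc(C(=O)Nc3ccccc3N)cc2)CC1`: 52.6%

Among the three, compound 3 stands highest. Both the step of a number 13.2 percentage points higher from compound 1 to compound 3 (beyond the scatter) and the step of a number 32 percentage points higher from compound 2 to compound 3 (beyond the scatter) lie beyond the scatter, so compound 3 is the strongest of the measured set, and compound 2 the weakest, as the step of a number 18.8 percentage points lower from compound 1 to compound 2 (beyond the scatter) also shows.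

The unmeasured compound 4, `Nc1ccccc1NC(=O)c1ccc(CSC(=S)N2CCN(c3ccccc3)CC2)cc1`, differs from compound 3 in one place: phenyl in place of methyl on an amine nitrogen in a ring. Within the data shown here, two measured steps bear on this change. Replacing 4-methoxyphenyl with methyl gave a number 13.2 percentage points higher from compound 1 to compound 3 (beyond the scatter), a modest gain, while replacing benzyl with methyl gave a number 32 percentage points higher from compound 2 to compound 3 (beyond the scatter), a large gain. The phenyl of compound 4 resembles the 4-methoxyphenyl of compound 1 far more than the benzyl of compound 2, so reversing the smaller of these gains is the closer guide. In this assay compound 4 is therefore expected to fall back from compound 3 by a modest step, a number 12.6 percentage points lower from compound 3 to compound 4 (beyond the scatter). Compound 4 is estimated at 40%, with a likely range from 26% to 54%.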

Compound 4, a percentage reported as inhibition, at one concentration (the size of the read-out at that concentration, not a potency): 62.2%
Compound 4: the middle estimate sits 22.2 percentage points below what was measured, outside the stated range (above it).
By their numbers in this assay, from the lowest: compound 2; then compound 1; then compounds 3 and 4 (each within the scatter of the next).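

In this assay phenyl in place of methyl on the amine nitrogen in the ring gives a number 9.6 percentage points higher from compound 3 to compound 4 (within the scatter) and so shows that an aromatic ring carried directly on this nitrogen does not in itself cost activity against methyl. The other two steps show that the group's details matter at this position: phenyl in place of benzyl gives a number 41.6 percentage points higher from compound 2 to compound 4 (beyond the scatter) and hydrogen in place of methoxy on an aromatic carbon gives a number 22.8 percentage points higher from compound 1 to compound 4 (beyond the scatter) within the same series. Nothing available explains these differences.

On these data alone, it remains open whether a fluoro or hydroxy group on the phenyl would behave like methoxy or like hydrogen. As far as these compounds go, it also remains open whether an ethyl group or a longer chain on the same nitrogen would follow methyl or benzyl.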